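Swapping Carboxy for Acetoxymethyl in a Closely Matched Trio

The source may hold more compounds than are shown below. What is called first, only, known or untested is meant among the compounds shown, and "the series" means these compounds.

Of the compounds shown here, three sharing one core have been measured in a functional assay on SK-BR-3 cells (Homo sapiens) for cytotoxicity, read by sulforhodamine B assay, with a stated time of 3 days; on this read-out higher numbers stand for an effect only at larger amounts of compound and lower numbers for an effect already at smaller amounts. Compound 1 `CCOCc1c(C)coc1-c1ccc2c(c1OC)CCCC2(C)C` gives 19.8 uM, compound 2 `COC(=O)c1c(C)coc1-c1ccc2c(c1OC)CCCC2(C)C` gives 27.1 uM, and compound 3 `COc1c(-c2occ(C)c2C(=O)O)ccc2c1CCCC2(C)C` gives 25.5 uM. Compound 3 lies within the usual scatter of both others, so these numbers do not rank the three.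

Compound 4 `COc1c(-c2occ(C)c2COC(C)=O)ccc2c1CCCC2(C)C` has acetoxymethyl in place of carboxy on an aromatic carbon. Among the measured compounds shown here, no measured compound carries acetoxymethyl, so the closest guide is what the other exchanges at this aromatic carbon did. Putting methoxycarbonyl in place of ethoxymethyl gave a 1.4-fold higher number from compound 1 to compound 2 (0.14 log units; within the scatter). Putting carboxy in place of ethoxymethyl gave a 1.3-fold higher number from compound 1 to compound 3 (0.11 log units; within the scatter). Putting hydrogen in place of methyl on an oxygen next to a carbonyl group gave a 1.1-fold lower number from compound 2 to compound 3 (0.03 log units; within the scatter). All three steps are small enough to be indistinguishable from repeat-measurement noise, though three compounds are a thin basis and a new group could still behave differently.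

No shift beyond the scatter is therefore expected in this assay, and no firm direction can be assigned. The estimated step is a 1.1-fold lower number from compound 3 to compound 4 (0.04 log units; within the scatter). For compound 4 the expected value is 23 uM, with an estimated range from 13 uM to 40 uM.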

Compound 4, concentration for half-maximal effect: 14 uM
Compound 4: the middle estimate sits 1.6-fold (0.22 log units) above what was measured; the measured number falls inside the stated range.
By their numbers in this assay, from the lowest: compounds 4, 1, 3 and 2 (each within the scatter of the next).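

In this assay, acetoxymethyl on this aromatic carbon of the five-membered ring gives a 1.8-fold lower number from compound 3 to compound 4 (0.26 log units; within the scatter) when it replaces carboxy, a 1.9-fold lower number from compound 2 to compound 4 (0.29 log units; within the scatter) when it replaces methoxycarbonyl and a 1.4-fold lower number from compound 1 to compound 4 (0.15 log units; within the scatter) when acetyl replaces ethyl on the side-chain oxygen, and all three steps lie within the scatter. The exchange for carboxy goes from 1 hydrogen-bond donor to 0 hydrogen-bond donors and from 3 heavy atoms to 5 heavy atoms, yet it still gives no step beyond the scatter, so the position has now held four different groups without any pair of them standing clearly apart. No measurement shown here offers an explanation for these numbers.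

Every group shown at this position contains oxygen, so it remains open whether an amine, a hydroxymethyl group or a longer hydrocarbon chain would give a step beyond the scatter. On these data alone, it also remains open whether these small steps would stay equally small on a core with a different group in place of the neighbouring methyl group.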